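A few compounds are considered here, and "the series" means these few. Any claim that something is new, unique, unknown or untested is made for them only; others in the source may bear on it.

Going by the values given here, in an assay for inhibition of 3-hydroxy-3-methylglutaryl-coenzyme A reductase (Rattus norvegicus) (on this read-out higher numbers stand for weaker inhibition and lower numbers for stronger inhibition), compound 2 `O=C1C[C@H](O)C[C@@H](/C=C/c2c(Cl)cc(Cl)cc2-c2ccccc2)O1` gives 80 nM, the higher of the two numbers measured so far, while compound 1 `Cc1cc(-c2cc(Cl)cc(Cl)c2/C=C/[C@@H]2C[C@@H](O)CC(=O)O2)ccc1F` gives 29 nM. Compound 3 `Cc1ccccc1-c1cc(Cl)cc(Cl)c1/C=C/[C@@H]1C[C@@H](O)CC(=O)O1` differs from compound 2 by methyl in place of hydrogen on an aromatic carbon. Among the compounds with values here, the one measured step that bears on this change, a 2.8-fold higher number from compound 1 to compound 2 (0.44 log units; beyond the scatter), shows that removing both substituents from the outer ring raised the number modestly, and compound 3 puts one methyl back on that ring. For compound 3 a modest step back down is therefore expected, a 1.8-fold lower number from compound 2 to compound 3 (0.25 log units; within the scatter). Compound 3 is estimated at 45 nM, within a range of 15 nM to 130 nM.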

Compound 3, half-maximal inhibitory concentration: 370 nM
Beside the measured number, compound 3's estimate is 8.2-fold (0.91 log units) below it; measured number above the stated range.
By their numbers in this assay, from the lowest: compound 1; then compound 2; then compound 3.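

In this assay the change from phenyl to 2-methylphenyl weakens inhibition, with a 4.6-fold higher number from compound 2 to compound 3 (0.67 log units; beyond the scatter) on this one change, so adding a methyl to the outer ring does not by itself move the number toward that of compound 1. The gap is wider still against the 4-fluoro-3-methylphenyl group, with a 13-fold higher number from compound 1 to compound 3 (1.11 log units; beyond the scatter) between these two outer rings. Nothing at hand explains this rise. Open, going by these compounds, is whether the rise is particular to methyl, since a fluorine atom or a methoxy group in that place could behave differently.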